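The compounds below may be only part of what the source reports. "The series", "measured", "known", "first", "only" and "open" are said of these compounds alone.

Measured so far:
compound 1 `CCCOc1ccc(C2CNC(=O)CS2)cc1` gives 2400 nM
compound 2 `CCOc1ccc(C2CNCCS2)cc1` gives 2100 nM

Both numbers come from an assay on isolated protein for inhibition of Amine oxidase [flavin-containing] B (Homo sapiens), read by spectrophotometry; a lower number here means a stronger inhibitor, a higher number a weaker inhibitor. Compound 2 and compound 1 lie within the scatter of each other, so neither stands apart. Compound 3 `c1ccc(COc2ccc(C3CNCCS3)cc2)cc1` differs from compound 2 by phenyl in place of methyl on a saturated chain carbon bound to an oxygen on an aromatic ring. Going by the values given here, no measured pair shows this change, so its size is not known from these data. Since a whole aromatic ring enters, a step in this assay beyond the scatter, toward a lower number, seems more likely than none. The step expected here is a 7.0-fold lower number from compound 2 to compound 3 (0.85 log units; beyond the scatter). For compound 3 the estimate is 300 nM, with a range from 60 nM to 1500 nM.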

Compound 3, inhibition constant: 38 nM
For compound 3 the middle estimate is 7.9-fold (0.90 log units) above the measured one; measured number outside the range, below it.
By their numbers in this assay, from the lowest: compound 3; then compounds 2 and 1 (each within the scatter of the next).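

In this assay, phenyl in place of methyl on a saturated chain carbon bound to an oxygen on an aromatic ring brings a 55-fold lower number from compound 2 to compound 3 (1.74 log units; beyond the scatter) and so shows that this position responds strongly to the group it carries. Compound 1 and compound 2 could not show this, as they differ in more than one place. Nothing available explains the size of this step. Still open, going by these compounds, is whether a pyridine ring in place of phenyl, a chlorophenyl, or a longer chain carrying the phenyl would keep this lower number.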